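The source may report more compounds than this note shows. Statements on the series, on what has been measured and on what is new or still open speak of the compounds shown alone.

Compound 1, `CCCn1nc(-c2ccc(C(=O)OCC)cc2)c2ccccc21`: in a functional assay on cells (Platelet, Homo sapiens) for inhibition (on this read-out lower numbers stand for stronger inhibition and higher numbers for weaker inhibition), compound 1 gives > 10000 nM, which is a limit of the assay and not a number.
Compound 2, `CCCCn1nc(-c2ccc(C(=O)OCC)cc2)c2ccccc21`: in this assay compound 2 gives > 10000 nM, again a limit and not a number.

Compound 2 thus stands at the limit of this assay, and both values shown sit at the limit of > 10000 nM in this assay, at which 2 of the 2 values shown sit. Among the measured compounds shown here, the only measured step, a step that the two limits leave unreadable from compound 1 to compound 2, is therefore unreadable: a limit on each side leaves its size unknown.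

Compound 3, `CCOC(=O)c1ccc(-c2nn(-c3ccccc3)c3ccccc23)cc1`, differs from compound 2 by phenyl in place of butyl on an aromatic nitrogen. No measured step concerns a phenyl in place of an alkyl chain on this aromatic nitrogen, so nothing shown indicates the direction or size of the change in this assay. The estimate for compound 3 rests only on the limit at which compound 2 stands; compound 3 is expected to give about 15000 nM, between 3000 nM and 60000 nM, with the estimated step that the limit leaves unreadable from compound 2 to compound 3 most likely again ending at a limit rather than a number.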

Compound 3, half-maximal inhibitory concentration: > 10000 nM
Compound 3 gave a limit, no number; the forecaster's own chance of this, stated with the estimate: 75%; the middle value does not contradict the limit.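

Compound 3 gives > 10000 nM in this assay, a limit and not a number. The steps among compound 1, compound 2 and compound 3 therefore cannot be read: the limit of > 10000 nM in this assay, at which 3 of the 3 values shown sit.

Going by these compounds, whether swapping propyl, butyl or phenyl on the aromatic nitrogen changes inhibition at all remains open.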